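The compounds below may be only part of what the source reports. "The series", "measured", "known", "first", "only" and "open" are said of these compounds alone.

Measured compounds in a functional assay on HeLa cells (Homo sapiens) for antiproliferative activity, read by MTT assay, with a stated time of 6 days; on this read-out higher numbers stand for weaker inhibition and lower numbers for stronger inhibition:
- compound 1 `CC(=O)O[C@@H]1C=CC(=O)O[C@@H]1[C@@H](COC(=O)c1ccc([N+](=O)[O-])cc1)OC(C)=O`: 4650 nM
- compound 2 `O=C1C=C[C@@H](OCc2ccccc2)[C@@H]([C@@H](COC(=O)/C=C/c2ccccc2)OCc2ccccc2)O1`: 9510 nM
- compound 3 `COc1ccc(/C=C/C(=O)OC[C@@H](OCc2ccccc2)[C@H]2OC(=O)C=C[C@H]2OCc2ccccc2)cc1`: 1080 nM

Compound 3 has the lowest number of the three in this assay. Compound 4 `O=C1C=C[C@@H](OCc2ccccc2)[C@@H]([C@@H](COC(=O)/C=C/c2ccc([N+](=O)[O-])cc2)OCc2ccccc2)O1` differs from it in one place, with nitro in place of methoxy on an aromatic carbon, para to a large group: nitro in place of methoxy on an aromatic carbon. Among the measured compounds shown here, the only measured step at this place is an 8.8-fold lower number from compound 2 to compound 3 (0.94 log units; beyond the scatter), where methoxy took the place of hydrogen. No nitro has been measured on this cinnamate-type ester, so that step is only a rough guide. Losing the methoxy of compound 3 (1080 nM) leads one to expect a moderate move toward a higher number, probably smaller than the measured step. The expected change is a 2.8-fold higher number from compound 3 to compound 4 (0.44 log units; beyond the scatter). Compound 4 is estimated at 3000 nM, within an expected range of 800 nM to 10000 nM.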

Compound 4, half-maximal inhibitory concentration: 2650 nM
Compound 4: the middle estimate sits 1.1-fold (0.05 log units) above what was measured; low and high end bracket the measured number.
By their numbers in this assay, from the lowest: compound 3; then compounds 4 and 1 (each within the scatter of the next); then compound 2.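

In this assay, among the compounds shown here, nitro in place of hydrogen on this aromatic carbon brings a 3.6-fold lower number from compound 2 to compound 4 (0.55 log units; beyond the scatter), so methoxy is not the only group here that gives a lower number than hydrogen. Nitro in place of methoxy still brings a 2.5-fold higher number from compound 3 to compound 4 (0.39 log units; beyond the scatter), so the two groups are not interchangeable at this position, and methoxy gives the lower number of the pair. Nothing measured here explains this difference. The compounds shown leave open whether an amine or a chlorine on this carbon would also give a lower number than hydrogen.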